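Swapping dichlorophenyl for dimethoxyphenyl on the enone carbonyl

A few compounds are considered here, and "the series" means these few. Any claim that something is new, unique, unknown or untested is made for them only; others in the source may bear on it.

Three pyrazole chalcone analogues were examined in a functional assay on SN12C cells (Homo sapiens) for cytotoxicity, read by sulforhodamine B assay, with a stated time of 48 h, tested at 0.01 uM; on this read-out higher numbers stand for a weaker effect at the one concentration tested and lower numbers for a stronger effect. Compound 1 `COc1ccc(-c2cc(/C=C/C(=O)c3ccc(OC)c(OC)c3)[nH]n2)cc1` gives 95%, compound 2 `COc1cc(-c2cc(/C=C/C(=O)c3ccc(Cl)c(Cl)c3)[nH]n2)cc(OC)c1OC` gives 98%, and compound 3 `COc1ccc(-c2cc(/C=C/C(=O)c3ccc(N)cc3)[nH]n2)cc1OC` gives 101%. Compound 2 thus sits among three readings that all lie within the usual scatter of one another, so none of them is distinguished from the others in this assay. Compound 4 `COc1ccc(C(=O)/C=C/c2cc(-c3cc(OC)c(OC)c(OC)c3)n[nH]2)cc1OC` has not yet been tested. Its difference from compound 2 is 3,4-dimethoxyphenyl in place of 3,4-dichlorophenyl on a carbonyl carbon. Since compound 1 and compound 3, which carry oxygen- or nitrogen-bearing groups on that ring, give readings within the scatter of compound 2, the step of a number 1 percentage points lower from compound 2 to compound 4 (within the scatter) is expected to be none beyond the scatter. Compound 4 is therefore estimated at 97%, with a range from 88% to 106%.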

Compound 4, a percentage reported as activity, at one concentration (the size of the read-out at that concentration, not a potency): 99%
For compound 4 the middle estimate is 2 percentage points below the measured one; the measured number falls inside the stated range.
By their numbers in this assay, from the lowest: compounds 1, 2, 4 and 3 (each within the scatter of the next).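

Among the compounds shown here, the step of a number 1 percentage points higher from compound 2 to compound 4 (within the scatter) in this assay is the first direct comparison at this position, where the two compounds differ only on the carbonyl carbon. It shows that, at the one concentration tested, 3,4-dimethoxyphenyl and 3,4-dichlorophenyl cannot be told apart there. No measured evidence bears on this result. Going by these compounds, whether a carboxylic acid or a longer alkyl chain in place of that ring would give a reading beyond the scatter remains open, as does whether this exchange would matter at other concentrations.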